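From Compound 2 to Compound 3: A Side-Chain Swap

The compounds below may be only part of what the source reports. "The series", "measured", "known", "first", "only" and "open" are said of these compounds alone.

- compound 1 `Cc1oc(-c2ccccc2Cl)nc1CN1CCC(C(=O)NCCCN2C[C@H](C)C[C@H](C)C2)CC1`: 16500 nM
- compound 2 `Cc1ccccc1-c1nc(CN2CCC(C(=O)NCCCN3CCC(C)CC3)CC2)c(C)o1`: 12300 nM

In an ADME assay on Huh7.5.1 cells (Homo sapiens) for cytotoxicity, read by ATP content, with a stated time of 48 h (on this read-out lower numbers stand for higher toxicity in this test and higher numbers for lower toxicity in this test), compound 2 gives 12300 nM, which lies within the scatter of compound 1 at 16500 nM. Compound 3 `Cc1ccccc1-c1nc(CN2CCC(C(=O)NCCN3C[C@H](C)C[C@H](C)C3)CC2)c(C)o1` has not yet been measured. It differs from compound 2 as follows: 3,5-dimethylpiperidin-1-yl in place of (4-methylpiperidin-1-yl)methyl on a saturated chain carbon, two bonds along the chain from an amide-type nitrogen. This places 3,5-dimethylpiperidin-1-yl in place of (4-methylpiperidin-1-yl)methyl on a saturated chain carbon, two bonds along the chain from an amide-type nitrogen. Among the measured compounds shown here, no measured pair shows this change alone, so no shift beyond the scatter is expected in this assay, in either direction. The expected size is a 1.1-fold higher number from compound 2 to compound 3 (0.06 log units; within the scatter). For compound 3 the estimated value is 14000 nM, with an expected range of 7000 nM to 28000 nM.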

Compound 3, half-maximal cytotoxic concentration: 24400 nM
Compound 3: the middle estimate sits 1.7-fold (0.24 log units) below what was measured; measured number inside the range.
By their numbers in this assay, from the lowest: compounds 2, 1 and 3 (each within the scatter of the next).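

In this assay, among the compounds shown here, the swap of (4-methylpiperidin-1-yl)methyl for 3,5-dimethylpiperidin-1-yl on this saturated chain carbon gives a 2.0-fold higher number from compound 2 to compound 3 (0.30 log units; within the scatter) and so provides the first measured step at this position. Both groups are six-membered non-aromatic rings with the same heavy-atom count, and exchanging one for the other produces no shift that can be told from the scatter. The compounds shown leave open whether a morpholin-4-yl group or a carboxylic acid at this place would move the number beyond the scatter. No available evidence bears on the size of this step.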